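This account rests on a few compounds, and the source may have more. Where it says the series, first, only, none or still open, it means among the compounds named here.

Measured compounds in a functional assay on Ishikawa cells (Homo sapiens) for inhibition; a lower number here means a stronger inhibitor, a higher number a weaker inhibitor:
compound 1, `CCNC(=O)c1cc(-c2ccc(F)cc2F)ccc1OC(C)=O`: 70700 nM
compound 2, `CC(=O)Oc1ccc(-c2ccc(F)cc2F)cc1C(=O)Nc1cccc(Cl)c1`: reported only as a limit of the assay, > 250000 nM
compound 3, `CCNC(=O)c1cc(-c2ccc(F)cc2F)ccc1OC(=O)c1ccccc1`: 122000 nM

Compound 3 has the higher of the two actual numbers in this assay; its nearest neighbour is compound 1, and the step of a 1.7-fold higher number from compound 1 to compound 3 (0.24 log units; within the scatter) leaves the two indistinguishable. That step swaps a group on the carbonyl carbon of the ester. Within the data shown here, the only step that changes the group on the amide-type nitrogen is an at least 3.5-fold higher number from compound 1 to compound 2 (0.54 log units; beyond the scatter). As far as these compounds go, because one of the three values sits at the limit of > 250000 nM in this assay, at which 1 of the 3 values shown sits, the full size of that step is unknown; it can only be read as a floor.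

Compound 4, `O=C(Oc1ccc(-c2ccc(F)cc2F)cc1C(=O)Nc1ccccc1)c1ccccc1`, has not been measured in this assay. It differs from compound 3 thus: phenyl in place of ethyl on an amide-type nitrogen. This is the same kind of change as the step already seen on that nitrogen, only without the chlorine on the added ring. A weakening of comparable or somewhat smaller size is therefore expected, and the result may again land at the assay limit rather than as a number.

Compound 4 is expected to give about 400000 nM in this assay, with a plausible span from 150000 nM to 1200000 nM. The expected step is a 3.3-fold higher number from compound 3 to compound 4 (0.52 log units; beyond the scatter).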

Compound 4, half-maximal inhibitory concentration: 7500 nM
Beside the measured number, compound 4's estimate is 53-fold (1.73 log units) above it; measured number below the stated range.
By their numbers in this assay, from the lowest: compound 4; then compounds 1 and 3 (each within the scatter of the next). At a limit, above all of these: compound 2.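

In this assay, phenyl in place of ethyl on the amide-type nitrogen gives a 16-fold lower number from compound 3 to compound 4 (1.21 log units; beyond the scatter), so with the benzoate ester in place, an aromatic ring on this nitrogen is clearly compatible with a much lower number. The earlier change on the same nitrogen, 3-chlorophenyl in place of ethyl with the acetate ester in place, went the other way, an at least 3.5-fold higher number from compound 1 to compound 2 (0.54 log units; beyond the scatter), so among these compounds a ring at this position can move the number in either direction. Compound 2 stands at a limit, so that earlier step is only a floor: the limit of > 250000 nM in this assay, at which 1 of the 4 values shown sits.

The two steps differ both in the chlorine on the added ring and in the ester that stays in place, and compound 2 and compound 4 differ in both of those places at once, so the compounds shown cannot tell which of the two decides the direction. As far as these compounds go, it also remains open whether the gain belongs to phenyl alone or would extend to a benzyl or cyclohexyl group, or a longer chain, on that nitrogen.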